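This account rests on a few compounds, and the source may have more. Where it says the series, first, only, none or still open, it means among the compounds named here.

Compound 1, `COc1ccccc1N1CCN(CCCCNC(=O)c2nsc3ccccc23)CC1`: in an assay on brain for binding affinity to Adrenergic receptor alpha-1 (Rattus norvegicus), read by radioligand binding (a lower number here means a stronger inhibitor, a higher number a weaker inhibitor), compound 1 gives 6.4 nM.
Compound 2, `CN(CCCCN1CCC(C(=O)c2ccc(F)cc2)CC1)C(=O)c1nsc2ccccc12`: in this assay compound 2 gives 3.2 nM.

Among the compounds with values here, of the two numbers known, compound 2 has the lower one, and compound 1 is the nearest to it; the gap between them lies within the usual scatter, so neither can be called the stronger binder. Compound 3, `CN(CCCCN1CCC(c2noc3cc(F)ccc23)CC1)C(=O)c1nsc2ccccc12`, has not yet been measured. It differs from compound 2 in one place: a group of 10 heavy atoms (7 carbon, 1 nitrogen, 1 oxygen, 1 fluorine; one five-membered aromatic ring with 2 hetero atoms, one six-membered aromatic ring of carbon only) in place of a group of 9 heavy atoms (7 carbon, 1 oxygen, 1 fluorine; one six-membered aromatic ring of carbon only), on a saturated ring carbon. Within the data shown here, no pair of measured compounds shows a step of this kind, so there is no measured step to build on. With compound 2 standing at 3.2 nM in this assay and nothing in the data pointing either way, the change is expected to move the number little, if at all beyond the scatter. Compound 3 is therefore estimated at 3 nM in this assay, within a range from 0.8 nM to 12 nM. The expected step is a 1.1-fold lower number from compound 2 to compound 3 (0.03 log units; within the scatter).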

Compound 3, half-maximal inhibitory concentration: 174 nM
Compound 3: middle estimate off by 58-fold (1.76 log units), on the low side; measured number above the stated range.
By their numbers in this assay, from the lowest: compounds 2 and 1 (each within the scatter of the next); then compound 3.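

This is the first step shown at this saturated ring carbon, and it shows that the position is far from indifferent to what it carries. Replacing the (4-fluorophenyl)carbonyl group with the fused group containing a five-membered aromatic ring gives a 54-fold higher number from compound 2 to compound 3 (1.74 log units; beyond the scatter) in this assay. Nothing measured here explains why the number rises so far.

The change swaps the whole group at once, so the compounds shown leave open whether the rise goes with the new five-membered aromatic ring or with the departure of the carbonyl. A plain phenyl group or a 4-fluorobenzyl group on the same ring carbon would help separate these two parts of the change.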